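This account rests on a few compounds, and the source may have more. Where it says the series, first, only, none or still open, it means among the compounds named here.

Compound 2, with the structure `Cn1ncc(Cl)c1-c1cc(C(=O)N[C@@H]2CN[C@H](CCN3CCC(O)CC3)C[C@H]2c2ccc(Cl)c(Cl)c2)oc1Cl`, gives 13700 nM in a functional assay on HCT-116 cells (Homo sapiens) for antiproliferative activity, read by sulforhodamine B assay, with a stated time of 72 h (a higher number here means a weaker inhibitor, a lower number a stronger inhibitor), the highest of the two numbers recorded here. Its nearest neighbour is compound 1, `Cn1ncc(Cl)c1-c1cc(C(=O)N[C@@H]2CN[C@H](CC(=O)NC3CC3)C[C@H]2c2ccc(Cl)c(Cl)c2)oc1Cl`, which in this assay gives 740 nM. For the measured compounds named here, the one step joining them, a 19-fold higher number from compound 1 to compound 2 (1.27 log units; beyond the scatter), is large and beyond the scatter. Compound 3, `C=CC[C@@H]1C[C@@H](c2ccc(Cl)c(Cl)c2)[C@H](NC(=O)c2cc(-c3c(Cl)cnn3C)c(Cl)o2)CN1`, has not yet been measured; it differs from compound 2 by vinyl in place of (4-hydroxypiperidin-1-yl)methyl on a saturated chain carbon bound to a saturated ring carbon. Going by the values given here, no measured step repeats this exact change, so only the step from compound 1 to compound 2 offers guidance, and it shows that the (4-hydroxypiperidin-1-yl)methyl group carries a markedly higher number than the cyclopropylcarbamoyl group. Removing that group in favour of vinyl is therefore expected to move the number downward, though the absence of an amide in compound 3 leaves the size uncertain. Compound 3 is estimated at 2500 nM, within 600 nM to 10000 nM, a step of a 5.5-fold lower number from compound 2 to compound 3 (0.74 log units; beyond the scatter).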

Compound 3, half-maximal inhibitory concentration: 780 nM
The estimate for compound 3 lay 3.2-fold (0.51 log units) above the measured number; the measured number falls inside the stated range.
By their numbers in this assay, from the lowest: compounds 1 and 3 (each within the scatter of the next); then compound 2.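

In this assay, the change from 2-(4-hydroxypiperidin-1-yl)ethyl to allyl proves large (an 18-fold lower number from compound 2 to compound 3 (1.24 log units; beyond the scatter)). The comparison with compound 1 adds that vinyl and cyclopropylcarbamoyl cannot be told apart on this saturated chain carbon (a 1.1-fold higher number from compound 1 to compound 3 (0.02 log units; within the scatter)), so among these three compounds only the (4-hydroxypiperidin-1-yl)methyl group stands apart, and a side chain with no amide serves as well here as one with an amide. Nothing measured beyond these numbers speaks to why the piperidine-bearing chain differs.

The compounds shown do not separate the contributions of the piperidine ring, its hydroxyl and its nitrogen to the higher number of compound 2. Going by these compounds, how a primary amine, a carboxylic acid or a longer saturated alkyl chain would read at this place also remains open.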